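Three Analogues at the Assay Limit and a Shortened Side Chain

The source may hold more compounds than are shown below. What is called first, only, known or untested is meant among the compounds shown, and "the series" means these compounds.

compound 1, `Nc1cccc(Nc2c(C(=O)NCc3ccc(F)cc3)nc(Br)c3cccnc23)c1`: > 10000 nM
compound 2, `N[C@H]1CC[C@H](Nc2c(C(=O)NCc3ccco3)nc(Br)c3cccnc23)CC1`: > 10000 nM
compound 3, `CC(C)(C)OC(=O)N1CCN(c2c(C(=O)NCc3ccc(F)cc3)nc(Br)c3cccnc23)CC1`: > 10000 nM

All three compounds share one core and were tested in a functional assay on HCT-116 cells (Homo sapiens) for cytotoxicity, read by MTT assay, with a stated time of 72 h; a higher number here means a weaker inhibitor, a lower number a stronger inhibitor. For compound 1 the value > 10000 nM is a limit of the assay, not a measured number. Compound 2 also stops at the limit, > 10000 nM. Compound 3 likewise gives only the limit > 10000 nM. Taken together, the picture is summed up by the limit of > 10000 nM in this assay, at which 3 of the 3 values shown sit: none of the three shows measurable inhibition, and compound 1 stands on the same footing as compound 2 and compound 3, with nothing to separate them.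

Compound 4, `NCCNc1c(C(=O)NCc2ccc(F)cc2)nc(Br)c2cccnc12`, is the next compound to be measured in this assay. It differs from compound 1 in one place: 2-aminoethyl in place of 3-aminophenyl on a nitrogen on an aromatic ring. Among the measured compounds shown here, no step between measured compounds exists here, so there is no measured change to lean on, and with every known value sitting at the limit there is no sign that a change of this kind moves the read-out. The expected step that the limit leaves unreadable from compound 1 to compound 4 is therefore none beyond the scatter, and compound 4 is most likely to reach only the limit again. Compound 4 is expected to give roughly 15000 nM, with a range from 5000 nM to 50000 nM in this assay.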

Compound 4, half-maximal inhibitory concentration: > 20000 nM
Compound 4: no number, only a limit (the forecaster's own chance of this, stated with the estimate: 80%); middle value at least 1.3-fold (0.12 log units) from the limit.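

Compound 1 and compound 4 both end at a limit of the assay, and no step can be read for 2-aminoethyl in place of 3-aminophenyl. The compounds shown leave open whether any change at this nitrogen, or elsewhere on the shared core, gives a measurable value in this assay.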